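From Compound 3 to Compound 4: An Expected Half-Life

The source may hold more compounds than are shown below. What is called first, only, known or untested is meant among the compounds shown, and "the series" means these compounds.

Compound 1 `CCC(CC)(c1nnc[nH]1)c1ccc(-c2ccc3cc(F)cc(F)c3c2)[nH]c1=O` has in an ADME assay on microsomes from liver (Rattus norvegicus) for metabolic stability (a higher number here means that the compound lasts longer, a lower number that the compound disappears faster), a half-life of 1.26 h. Compound 2 `CCn1ncc2c(F)cc(-c3ccc(C(CC)(CC)c4nnc(C)[nH]4)c(=O)[nH]3)cc21` reaches only the limit of > 3 h in this assay, so no number is known for it. Compound 3 `CC(C)C(Nc1nccs1)c1ccc(-c2ccc3cccc(F)c3c2)[nH]c1=O` gives 0.07 h in this assay, the lowest of the two numbers, far below compound 1 and beyond the scatter.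

Compound 4 `Cc1c[nH]c(C(c2ccc(-c3ccc4cccc(F)c4c3)[nH]c2=O)C(C)C)n1` has not been measured. It differs from compound 3 in one place: 4-methyl-1H-imidazol-2-yl in place of (1,3-thiazol-2-yl)amino on a saturated chain carbon bound to an aromatic carbon and a saturated chain carbon. Among the compounds with values here, no step between measured compounds carries this change, so the direction rests on expectation alone. A moderate rise, larger than the scatter, is expected for the step of a 4.3-fold higher number from compound 3 to compound 4 (0.63 log units; beyond the scatter). Compound 4 is therefore estimated at 0.3 h, within a range from 0.08 h to 1.2 h.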

Compound 4, half-life: < 0.0667 h
Compound 4 gave a limit, no number (the forecaster's own chance of this, stated with the estimate: 5%); at least 4.4-fold (0.65 log units) between middle value and limit.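

Compound 4 gives a limit and not a number: the limit of < 0.0667 h in this assay, at which 1 of the 4 values shown sits. In this assay, 4-methyl-1H-imidazol-2-yl in place of (1,3-thiazol-2-yl)amino on this saturated chain carbon gives an at least 1.0-fold lower number from compound 3 to compound 4 (0.02 log units; that floor lies within the scatter). The exchange of one five-membered aromatic ring for the other therefore brings no rise in half-life at this position, even though the floor of the step cannot establish a fall.

As far as these compounds go, how far compound 4 truly lies from compound 3 stays open. Also open, from the compounds shown here alone, is whether another group on this carbon, such as a primary amine or a carboxylic acid, would lengthen the half-life in this assay.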